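The source may report more compounds than this note shows. Statements on the series, on what has been measured and on what is new or still open speak of the compounds shown alone.

Working notes on the series. Compound 1 `C/C(=N\CC1CCCCC1)c1c(O)c2ccccc2[nH]c1=O` is the starting point. In an assay on isolated protein for inhibition of myosin-2 (Bos taurus), read by spectrophotometry, with a stated time of 24 min (on this read-out lower numbers stand for stronger inhibition and higher numbers for weaker inhibition), compound 1 gives >= 100000 nM, which is a limit of the assay and not a number. Compound 2 `C/C(=N\C(C)C)c1c(O)c2ccccc2oc1=O` shares the open-chain ketimine but carries a different core. In this assay compound 2 also gives >= 100000 nM, again a limit rather than a number. Compound 3 `C/C(=N\Cc1cccc(C)c1)c1c(O)c2ccccc2oc1=O` is built on the same core as compound 2; in this assay compound 3 gives 4900 nM. Within the data shown here, two of the three values shown thus sit at the same boundary, (the limit of >= 100000 nM in this assay, at which 2 of the 3 values shown sit), so compound 1 stands with compound 2 at the limit, while compound 3 is the one compound with a measured number.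

Compound 4 `C/C(=N\Cc1ccccc1)c1c(O)c2ccccc2[nH]c1=O` has not been measured yet. It differs from compound 1 by phenyl in place of cyclohexyl on a saturated chain carbon bound to a double-bonded nitrogen. Among the compounds above, the one with an aromatic ring on the saturated chain carbon bound to a double-bonded nitrogen, compound 3, returns a number, whereas compound 1 and compound 2 with non-aromatic groups there return limits. On that basis a step toward stronger inhibition is expected, though its size is uncertain and the value may still come back as a limit. The expected step is an at least 3.3-fold lower number from compound 1 to compound 4 (0.52 log units; beyond the scatter). For compound 4 the estimate in this assay is 30000 nM, between 8000 nM and 100000 nM.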

Compound 4, half-maximal inhibitory concentration: >= 100000 nM
Compound 4 gave a limit, no number; the forecaster's own chance of this, stated with the estimate: 40%; middle value at least 3.3-fold (0.52 log units) away from the limit.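

Among these compounds, compound 1 and compound 4 both return a limit rather than a number, so no step between them can be read: the limit of >= 100000 nM in this assay, at which 3 of the 4 values shown sit. On these data alone, it remains open whether phenyl in place of cyclohexyl on a saturated chain carbon bound to a double-bonded nitrogen changes inhibition on this shared core.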